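Hydrogen in place of methoxy on compound 2

The source may hold more compounds than are shown below. What is called first, only, known or untested is meant among the compounds shown, and "the series" means these compounds.

Compound 1 `CC(Nc1ccccc1Oc1ccc(Cl)cc1)=C1C(=O)CC(c2ccccc2)CC1=O`: 500 nM
Compound 2 `COc1cc(Oc2ccccc2NC(C)=C2C(=O)CC(c3ccccc3)CC2=O)ccc1N`: 33 nM

In a functional assay on HeLa cells (Homo sapiens) for antiproliferative activity, read by cell counting, with a stated time of 3 days (a lower number here means a stronger inhibitor, a higher number a weaker inhibitor), compound 2 holds the lower of the two numbers, 33 nM. Compound 3 `CC(Nc1ccccc1Oc1ccc(N)cc1)=C1C(=O)CC(c2ccccc2)CC1=O` differs from it by hydrogen in place of methoxy on an aromatic carbon, ortho to an amino group. Within the data shown here, the only measured step bearing on this is a 15-fold lower number from compound 1 to compound 2 (1.18 log units; beyond the scatter). That step is large, but it brings in 4-amino-3-methoxyphenyl as a whole, and the data do not separate the amino group from the methoxy. The amino group stays, so a small move to a higher number is expected: a 1.8-fold higher number from compound 2 to compound 3 (0.26 log units; within the scatter). For compound 3 the estimated value is 60 nM, with an expected range of 15 nM to 250 nM.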

Compound 3, half-maximal inhibitory concentration: 39 nM
Compound 3: middle estimate off by 1.5-fold (0.19 log units), on the high side; the measured number falls inside the stated range.
By their numbers in this assay, from the lowest: compounds 2 and 3 (each within the scatter of the next); then compound 1.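

In this assay, the methoxy ortho to the amino group can be replaced by hydrogen with no change beyond the scatter, a 1.2-fold higher number from compound 2 to compound 3 (0.07 log units; within the scatter). The earlier large step therefore resolves to the amino group, since amino in place of chloro alone gives a 13-fold lower number from compound 1 to compound 3 (1.11 log units; beyond the scatter), and the methoxy adds no measurable contribution. No supporting data bear on why this is so.

Still open, as far as these compounds go, is whether the amino group must remain a primary amine. An acetamide, a dimethylamino group or a hydroxyl in its place would test this.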